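Aryl amide swap on the azetidine urea series

This account rests on a few compounds, and the source may have more. Where it says the series, first, only, none or still open, it means among the compounds named here.

Compound 1 `C[C@H](NC(=O)c1cccc(F)c1)c1ccc(NC(=O)N2CC(c3ccc(N)nc3)C2)cc1` is the reference point; in a functional assay on A2780 cells (Homo sapiens) for antiproliferative activity, read by CellTiter-Glo, with a stated time of 72 h (a higher number here means a weaker inhibitor, a lower number a stronger inhibitor), compound 1 gives 7.6 nM. Compound 2 `C[C@H](NC(=O)c1ncccn1)c1ccc(NC(=O)N2CC(c3ccc(N)nc3)C2)cc1` carries the change pyrimidin-2-yl in place of 3-fluorophenyl on a carbonyl carbon and in this assay compound 2 gives 68 nM, a step of an 8.9-fold higher number from compound 1 to compound 2 (0.95 log units; beyond the scatter). Compound 3 `C[C@H](NC(=O)c1cccc(F)c1)c1ccc(NC(=O)N2CC(c3cncc(N)c3)C2)cc1` has a different core, the difference being (5-aminopyridin-3-yl in place of 6-aminopyridin-3-yl on a saturated ring carbon); in this assay compound 3 gives 240 nM, which is a step of a 32-fold higher number from compound 1 to compound 3 (1.50 log units; beyond the scatter) and leaves compound 3 with the highest number of the three measured.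

Compound 4 `C[C@H](NC(=O)c1ncccn1)c1ccc(NC(=O)N2CC(c3cncc(N)c3)C2)cc1` is not yet measured. It differs from compound 3 by pyrimidin-2-yl in place of 3-fluorophenyl on a carbonyl carbon, the same change made from compound 1 to compound 2, at a place described in identical words. For the measured compounds named here, because the step of an 8.9-fold higher number from compound 1 to compound 2 (0.95 log units; beyond the scatter) was beyond the scatter, the step from compound 3 to compound 4 is expected to be of similar size, an 8.8-fold higher number from compound 3 to compound 4 (0.94 log units; beyond the scatter), resting on the single measured pair and on no further data for the core of compound 3. Compound 4 is therefore estimated at 2100 nM in this assay, with a range from 700 nM to 6500 nM.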

Compound 4, half-maximal inhibitory concentration: 340 nM
Compound 4: middle estimate off by 6.2-fold (0.79 log units), on the high side; the measured number lies below the stated range.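

In this assay the change to pyrimidin-2-yl on a carbonyl carbon does not carry over at constant size from the core of compound 1 to the core of compound 3, where it gives a 1.4-fold higher number from compound 3 to compound 4 (0.15 log units; within the scatter), and the two steps differ: the same change on two cores in this assay, an 8.9-fold higher number (0.95 log units; beyond the scatter) from compound 1 to compound 2 and a 1.4-fold higher number (0.15 log units; within the scatter) from compound 3 to compound 4, 6.3-fold (0.80 log units) apart, beyond the scatter of two such steps

Read the other way, 5-aminopyridin-3-yl in place of 6-aminopyridin-3-yl on a saturated ring carbon still gives a step beyond the scatter with the pyrimidin-2-yl amide, a 5.0-fold higher number from compound 2 to compound 4 (0.70 log units; beyond the scatter), but it is smaller than with the 3-fluorophenyl amide: the same change on two cores in this assay, a 32-fold higher number (1.50 log units; beyond the scatter) from compound 1 to compound 3 and a 5.0-fold higher number (0.70 log units; beyond the scatter) from compound 2 to compound 4, 6.3-fold (0.80 log units) apart, beyond the scatter of two such steps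

These two gaps are one non-additive result seen from two sides, resting on four compounds: it shows that the two changes are not independent here, but it does not show why, or whether the same holds for any other amide group.

From the compounds shown here alone, how a pyridin-2-yl or a cyclopropyl on the carbonyl carbon would behave on the two cores stays open. So does the effect of a pyridin-3-yl without the amino group on the saturated ring carbon.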